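This account rests on a few compounds, and the source may have more. Where it says the series, first, only, none or still open, it means among the compounds named here.

Working notes on the series. The shared core carries a urea and a pyrimidine ether; compound 1 `CNc1cc(Oc2ccc(NC(=O)Nc3cccc(C)c3)cc2)ncn1` and compound 2 `CCc1cccc(NC(=O)Nc2ccc(Oc3cc(NC)ncn3)cc2)c1` differ by methyl in place of hydrogen on a saturated chain carbon bound to an aromatic carbon. In an assay on isolated protein for inhibition of serine/threonine-protein kinase TNNI3K (Homo sapiens) (on this read-out higher numbers stand for weaker inhibition and lower numbers for stronger inhibition), compound 1 gives 1260 nM and compound 2 gives 200 nM, a step of a 6.3-fold lower number from compound 1 to compound 2 (0.80 log units; beyond the scatter). Compound 3 `O=C(Nc1ccc(Oc2cc(NCCO)ncn2)cc1)Nc1cccc(C(F)(F)F)c1` gives 32 nM in this assay; the difference between the cores of compound 3 and compound 1 is not broken down here. Compound 4 `C[C@H](O)CNc1cc(Oc2ccc(NC(=O)Nc3cccc(C(F)(F)F)c3)cc2)ncn1` is the next candidate and differs from compound 3 by methyl in place of hydrogen on a saturated chain carbon bound to an oxygen on a saturated carbon and a saturated chain carbon, the same kind of change as the earlier one, but around a different place: there the carbon was bound to an aromatic carbon, here to an oxygen on a saturated carbon and a saturated chain carbon. With the change sitting on the chain rather than the aryl ring, and resting on a single measured step, only a small step of a 1.3-fold lower number from compound 3 to compound 4 (0.11 log units; within the scatter) is expected for compound 4. The expected value of compound 4 in this assay is 25 nM, estimated between 8 nM and 80 nM.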

Compound 4, half-maximal inhibitory concentration: 32 nM
Estimate against measurement, compound 4: 1.3-fold (0.11 log units) below, and the stated range covers the measured number.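

The new step, 2-hydroxyethyl to 2-hydroxypropyl, reads no change at the digits printed from compound 3 to compound 4 (within the scatter) and stands apart from the earlier methyl step. In this assay, adding this methyl does not give one fixed step across the two cores: the same change on two cores in this assay, a 6.3-fold lower number (0.80 log units; beyond the scatter) from compound 1 to compound 2 and no change at the digits printed (within the scatter) from compound 3 to compound 4, 6.3-fold (0.80 log units) apart, beyond the scatter of two such steps. The two steps differ in both core and place of the methyl, so the gap cannot be assigned to either, and two steps set no rule for the series.

The compounds shown leave open how the chain on compound 4 responds when an amine or a carboxylic acid replaces the hydroxyl, or when a longer chain is used. On these data alone, the other stereoisomer of compound 4 also remains open.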